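Swapping One Ring Amine for Another on a Shared Core

The source may hold more compounds than are shown below. What is called first, only, known or untested is meant among the compounds shown, and "the series" means these compounds.

Compound 1 `CCN1CCN(c2cc(C)c3cc(NC(=O)c4ccccc4F)ccc3n2)CC1`: 32600 nM in a functional assay on MCF7 cells (Homo sapiens) for antiproliferative activity, read by MTT assay, with a stated time of 72 h; a higher number here means a weaker inhibitor, a lower number a stronger inhibitor
Compound 2 `CCc1ccccc1C(=O)Nc1ccc2nc(N3CCN(CC)CC3)cc(C)c2c1`: 15800 nM
Compound 3 `Cc1cc(N2CCCCC2)nc2ccc(NC(=O)c3ccc(Cl)c(Cl)c3)cc12`: 31100 nM

Among these three, compound 3 gives the second highest number, but its gap to compound 1 and its gap to compound 2 both lie within the scatter, so no order among them can be claimed. Compound 4 `CCN1CCN(c2cc(C)c3cc(NC(=O)c4ccc(Cl)c(Cl)c4)ccc3n2)CC1` differs from compound 3 by 4-ethylpiperazin-1-yl in place of piperidin-1-yl on an aromatic carbon. Among the measured compounds shown here, the only measured step, a 2.1-fold lower number from compound 1 to compound 2 (0.31 log units; beyond the scatter), alters a different group and does not bear on this exchange. For the measured compounds named here, no measured pair shows what this exchange does in this assay, so the expected step of a 1.0-fold lower number from compound 3 to compound 4 (0.02 log units; within the scatter) is none beyond the scatter. Compound 4 is therefore estimated at 30000 nM, with a range from 12000 nM to 75000 nM.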

Compound 4, half-maximal inhibitory concentration: 1380 nM
For compound 4 the middle estimate is 22-fold (1.34 log units) above the measured one; measured number below the stated range.
By their numbers in this assay, from the lowest: compound 4; then compounds 2, 3 and 1 (each within the scatter of the next, the first and the last beyond it).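

In this assay, the group on this aromatic carbon of the shared core proves able to shift the result strongly: 4-ethylpiperazin-1-yl in place of piperidin-1-yl gives a 23-fold lower number from compound 3 to compound 4 (1.35 log units; beyond the scatter) with the amide side unchanged. With 4-ethylpiperazin-1-yl held fixed, the amide side also counts, as 3,4-dichlorophenyl gives an 11-fold lower number from compound 2 to compound 4 (1.06 log units; beyond the scatter) in place of 2-ethylphenyl and a 24-fold lower number from compound 1 to compound 4 (1.37 log units; beyond the scatter) in place of 2-fluorophenyl. No measurement here offers an explanation for these steps. Still open, from the compounds shown here alone, is whether the ethyl chain on the piperazine is needed, and whether a morpholine ring or a piperazine bearing a longer chain would give a similar step.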